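This account rests on a few compounds, and the source may have more. Where it says the series, first, only, none or still open, it means among the compounds named here.

Measured so far:
compound 1 `COc1cc(N2C(N)=C(C#N)C(/C=C/c3ccccc3)C3=C2CC(C)(C)CC3=O)cc(OC)c1OC` in a functional assay on Ehrlich cells (Mus musculus) for cytotoxicity, tested at 10 ug/mL; a lower number here means a weaker effect, a higher number a stronger effect of the compound at the concentration tested: 10%
compound 2 `COc1cc(N2C(N)=C(C#N)C(c3ccc(Cl)cc3Cl)C3=C2CC(C)(C)CC3=O)cc(OC)c1OC` in this assay: 20%

Compound 2 stands at the top of these two numbers, but its nearest neighbour is compound 1 at the step of a number 10 percentage points higher from compound 1 to compound 2 (within the scatter), so the two are not separated. Compound 3 `COc1cc(N2C(N)=C(C#N)C(c3cccc([N+](=O)[O-])c3)C3=C2CC(C)(C)CC3=O)cc(OC)c1OC` is not yet measured; it differs from compound 2 in one place: 3-nitrophenyl in place of 2,4-dichlorophenyl on a saturated ring carbon. Among the compounds with values here, the only measured step that bears on this position is the exchange at the same saturated ring carbon, a number 10 percentage points higher from compound 1 to compound 2 (within the scatter), which stayed within the scatter. No step beyond the scatter is therefore expected, a number 5 percentage points lower from compound 2 to compound 3 (within the scatter). Compound 3 is estimated at 15%, within 0% to 40%.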

Compound 3, a percentage reported as activity, at one concentration (the size of the read-out at that concentration, not a potency): 5%
Compound 3: the middle estimate sits 10 percentage points above what was measured; the range from low to high includes it.
By their numbers in this assay, from the lowest: compounds 3, 1 and 2 (each within the scatter of the next, the first and the last beyond it).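

In this assay, within the data shown here, the saturated ring carbon now shows a first exchange that goes beyond the scatter: 3-nitrophenyl in place of 2,4-dichlorophenyl, a number 15 percentage points lower from compound 2 to compound 3 (beyond the scatter). The same 3-nitrophenyl is not separated from 2-phenylethenyl, a number 5 percentage points lower from compound 1 to compound 3 (within the scatter), so the position distinguishes only the two ends of this small set. No measurement at hand gives a reason for the step. Still open, on these data alone, is whether the chlorines carry the difference, which an unsubstituted phenyl or a 4-chlorophenyl at this carbon would test, and how an aliphatic amine there would read.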